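Chalcone series notes: bromophenyl for methoxyphenyl, expected read-out

The source may hold more compounds than are shown below. What is called first, only, known or untested is meant among the compounds shown, and "the series" means these compounds.

Compound 1 `COc1cccc(/C=C/C(=O)c2c(OC)cc(OC)cc2OC)c1` is run in a functional assay on NCI-H727 cells (Homo sapiens), read by fluorescence and BrdU incorporation, with a stated time of 48 h, tested at 10 uM (on this read-out higher numbers stand for a weaker effect at the one concentration tested and lower numbers for a stronger effect), where compound 1 gives 37%. Compound 2 `COc1cc(OC)c(C(=O)/C=C/c2ccccc2)c(OC)c1` gives 34% in this assay, and compound 3 `COc1cc(O)c(C(=O)/C=C/c2ccccc2OC)c(OC)c1` gives 43%. Among these three numbers compound 1 stands second highest; its nearest neighbour is compound 2 and its furthest is compound 3, and both gaps lie within the scatter, so the three read-outs cannot be told apart. Among the compounds with values here, the one recorded step, a number 3 percentage points lower from compound 1 to compound 2 (within the scatter), shows that hydrogen in place of methoxy on an aromatic carbon leaves the read-out essentially unchanged.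

Compound 4 `COc1cc(OC)c(C(=O)/C=C/c2ccc(Br)cc2)c(OC)c1` differs from compound 1 thus: 4-bromophenyl in place of 3-methoxyphenyl on a double-bonded chain carbon bound to a double-bonded chain carbon. Within the data shown here, no measured step covers bromine entering this ring; the only step that bears on the change is the loss of the methoxy in a number 3 percentage points lower from compound 1 to compound 2 (within the scatter), which stayed within the scatter. On that basis the step is expected as a number 2 percentage points lower from compound 1 to compound 4 (within the scatter), nothing beyond the scatter in either direction. Compound 4 is estimated at 35%, with a range from 20% to 55%.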

Compound 4, a percentage reported as activity, at one concentration (the size of the read-out at that concentration, not a potency): 39%
The estimate for compound 4 lay 4 percentage points below the measured number; low and high end bracket the measured number.
By their numbers in this assay, from the lowest: compounds 2, 1, 4 and 3 (each within the scatter of the next).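

In this assay, 4-bromophenyl in place of 3-methoxyphenyl on a double-bonded chain carbon bound to a double-bonded chain carbon gives a number 2 percentage points higher from compound 1 to compound 4 (within the scatter) and so adds a third substituent type to this ring without a read-out that can be told apart. Bromo in place of hydrogen on an aromatic carbon gives a number 5 percentage points higher from compound 2 to compound 4 (within the scatter) and thus shows the same for the ring without a substituent, so hydrogen, methoxy and bromo do not separate across compounds 1, 2 and 4. No measurement shown here offers an explanation for this flat result.

As far as these compounds go, whether an amine or a carboxylic acid on this ring would give a number beyond the scatter stays open. From the compounds shown here alone, with one concentration only, whether compounds 1, 2 and 4 would differ in the size of their effect at any other concentration also stays open.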